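This account rests on a few compounds, and the source may have more. Where it says the series, first, only, none or still open, it means among the compounds named here.

In a functional assay on the whole organism for inhibition, with Rattus norvegicus as the target, at a dose of 1 mg/kg by the oral route (a lower number here means a weaker effect, a higher number a stronger effect of the compound at the dose given), compound 1 `COc1ccc(-c2cc(OC)cc(C(=O)Nc3nn[nH]n3)n2)cc1` gives 25%, compound 2 `COc1cc(C(=O)Nc2nn[nH]n2)nc(-c2ccc(OC)c(OC)c2)c1` gives 18%, and compound 3 `COc1ccc(-c2cccc(C(=O)Nc3nn[nH]n3)n2)cc1` gives 12%. Compound 3 sits apart from compound 1 by a number 13 percentage points lower from compound 1 to compound 3 (beyond the scatter), whereas compound 3 and compound 2 lie within the scatter of each other. Compound 4 `CCc1ccc(-c2cccc(C(=O)Nc3nn[nH]n3)n2)cc1` arises from compound 3 through (ethyl in place of methoxy on an aromatic carbon). Within the data shown here, the closest precedent is the change from compound 1 to compound 3, where removing the methoxy cost a number 13 percentage points lower from compound 1 to compound 3 (beyond the scatter); adding a methoxy in the step from compound 1 to compound 2 gave a number 7 percentage points lower from compound 1 to compound 2 (within the scatter). Among the measured compounds shown here, no measured step exchanges methoxy for ethyl, so compound 4 is expected to show a step of no change at the digits printed from compound 3 to compound 4 (within the scatter), which is not beyond the scatter. Compound 4 is therefore estimated at 12%, within 0% to 28%.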

Compound 4, a percentage reported as inhibition, in the whole organism at one dose (the size of the read-out at that dose, not a potency): 39%
Beside the measured number, compound 4's estimate is 27 percentage points below it; measured number outside the range, above it.
By their numbers in this assay, from the lowest: compounds 3, 2 and 1 (each within the scatter of the next, the first and the last beyond it); then compound 4.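

In this assay, the group on the aromatic carbon para to a large group proves decisive: ethyl in place of methoxy gives a number 27 percentage points higher from compound 3 to compound 4 (beyond the scatter). The earlier steps shown here only added or removed a methoxy, whereas this one keeps the heavy-atom count and exchanges an oxygen for a carbon, losing one hydrogen-bond acceptor. Nothing available explains the rise. Open, going by these compounds, is whether a longer chain such as propyl on the same carbon would raise the number further. Also open, on these data alone, is whether ethyl would give a similar step on the core of compound 1.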